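The source may hold more compounds than are shown below. What is called first, only, known or untested is meant among the compounds shown, and "the series" means these compounds.

Compound 1 `COc1ccc(/C=C2\CN(CC(=O)O)c3c(Cl)cccc3C2=O)c(OC)c1OC`: 23.6%
Compound 2 `COc1cc(/C=C2\CN(CC(=O)O)c3ccc(C)cc3C2=O)cc(OC)c1`: 23.8%
Compound 3 `COc1cccc(/C=C2\CN(CC(=O)O)c3ccc(C)cc3C2=O)c1`: 14.4%

In an assay on HL-60 cells for inhibition of glutathione S-transferase P (Homo sapiens), read by spectrophotometry, tested at 20 uM (on this read-out higher numbers stand for more inhibition at the one concentration tested (going by the name of the read-out) and lower numbers for less inhibition), compound 3 gives 14.4%, the smallest of the three numbers, yet the gaps to compound 1 at 23.6% and to compound 2 at 23.8% both lie within the usual scatter, so the three compounds cannot be told apart on this read-out.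

Compound 4 `Cc1ccc2c(c1)C(=O)/C(=C/c1ccc(F)cc1)CN2CC(=O)O` is the next compound. Its difference from compound 3 is 4-fluorophenyl in place of 3-methoxyphenyl on a double-bonded chain carbon bound to a double-bonded ring carbon.

For the measured compounds named here, only one measured step touches the same aromatic ring: a number 9.4 percentage points lower from compound 2 to compound 3 (within the scatter), where a methoxy group was removed and the number moved within the scatter. Going by the values given here, no measured pair shows what happens when the whole ring is exchanged for a 4-fluorophenyl, so the expectation rests on that single step alone. Among the compounds with values here, since the one comparison on this ring stayed within the scatter, the step of a number 0.6 percentage points higher from compound 3 to compound 4 (within the scatter) is expected to be small as well, with no clear direction. Compound 4 is therefore estimated to give 15% in this assay, within a range of 4% to 27%.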

Compound 4, a percentage reported as inhibition, at one concentration (the size of the read-out at that concentration, not a potency): 16.1%
Compound 4: the middle estimate sits 1.1 percentage points below what was measured; measured number inside the range.
By their numbers in this assay, from the lowest: compounds 3, 4, 1 and 2 (each within the scatter of the next).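

The exchange of 3-methoxyphenyl for 4-fluorophenyl on a double-bonded chain carbon bound to a double-bonded ring carbon gives a number 1.7 percentage points higher from compound 3 to compound 4 (within the scatter) in this assay. This is the first step shown in which the whole aromatic group at this position is exchanged, rather than one methoxy group on it, and the two compounds cannot be told apart on this read-out. A methoxy group on this ring is therefore not required for compound 4 to give a number in the same range as compound 3, and no measurement shown offers an explanation for this result.

From the compounds shown here alone, whether a dimethylamino group on this aromatic ring, or a cyclohexyl ring in its place, would give a step beyond the scatter remains open. So does the effect of an amide in place of the carboxylic acid on the shared core.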